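The source may hold more compounds than are shown below. What is called first, only, known or untested is meant among the compounds shown, and "the series" means these compounds.

For the measured compounds named here, compound 2 `CC(C)(C)[C@H](NC(=O)c1cc(Cl)ccc1O)C(=O)Nc1cccc(C(F)(F)F)c1` is the only compound here with a number in a functional assay on K562 cells (Homo sapiens) for cytotoxicity, with a stated time of 72 h; a higher number here means a weaker inhibitor, a lower number a stronger inhibitor: compound 2 gives 5900 nM. Compound 1 `C[C@H](NC(=O)c1ccc(Cl)cc1O)C(=O)Nc1ccc(Cl)c(Cl)c1` gives only a limit, and in this assay compound 1 stands at > 12500 nM; it is the limit of > 12500 nM in this assay, at which 1 of the 2 values shown sits. Compound 3 `O=C(N[C@@H](CC1CCCCC1)C(=O)Nc1cccc(C(F)(F)F)c1)c1cc(Cl)ccc1O` differs from compound 2 by cyclohexylmethyl in place of tert-butyl on a saturated chain carbon bound to an amide-type nitrogen and a carbonyl carbon. Going by the values given here, no measured step matches this change, so no shift beyond the scatter is expected in either direction. The expected step of a 1.3-fold lower number from compound 2 to compound 3 (0.12 log units; within the scatter) is small. Compound 3 is estimated at 4500 nM, between 1500 nM and 14000 nM.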

Compound 3, half-maximal inhibitory concentration: 3400 nM
Compound 3: middle estimate off by 1.3-fold (0.12 log units), on the high side; the range from low to high includes it.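

In this assay, cyclohexylmethyl in place of tert-butyl on this saturated chain carbon gives a 1.7-fold lower number from compound 2 to compound 3 (0.24 log units; within the scatter), so a group with one six-membered non-aromatic ring of carbon only brings no shift beyond the scatter. For the compounds shown here, this is the only measured change at this place, so it rests on a single pair. Compound 1 stands only at a limit, and no step links it to the others: the limit of > 12500 nM in this assay, at which 1 of the 3 values shown sits.

From the compounds shown here alone, whether an amine or a carboxylic acid at this place would move the number beyond the scatter remains open.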